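The source may report more compounds than this note shows. Statements on the series, on what has been measured and on what is new or still open speak of the compounds shown alone.

Compound 1 `CC(=O)Oc1ccc(C(=O)/C=C/c2ccccc2)c(O)c1`: in a functional assay on MCF7 cells (Homo sapiens) for antiproliferative activity, with a stated time of 48 h (on this read-out lower numbers stand for stronger inhibition and higher numbers for weaker inhibition), compound 1 gives > 50000 nM, a limit of the assay and not a number.
Compound 2 `COc1ccc(C(=O)/C=C/c2ccccc2)c(O)c1I`: in this assay compound 2 gives > 50000 nM, likewise a limit and not a number.

Both values shown sit at a limit of this assay, so no number is known for either: the limit of > 50000 nM in this assay, at which 2 of the 2 values shown sit. Going by the values given here, compound 2 therefore stands at that limit; nothing in the numbers sets it apart from compound 1, and no measured step between the two can be stated.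

Compound 3 `COc1ccc(C(=O)/C=C/c2ccccc2)c(O)c1Br` differs from compound 2 in one place: bromo in place of iodo on an aromatic carbon. Among the compounds with values here, both measured compounds carry an acylated or methylated oxygen on the same ring and a hydroxy group, and both sit at the limit; the series so far gives no numbered potency to build on. Since compound 2 gives only a limit and the change is a halogen swap at one aromatic carbon, compound 3 is expected to stay at or near the limit, with no step beyond the scatter, and the step from compound 2 to compound 3 is estimated as a number no higher from compound 2 to compound 3 (the limit leaves the size open). Compound 3 is estimated at 50000 nM in this assay, within 15000 nM to 200000 nM, most likely again reported only as a limit.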

Compound 3, half-maximal inhibitory concentration: > 50000 nM
Compound 3 ended at the assay's limit (the forecaster's own chance of this, stated with the estimate: 80%); the middle value lies on the limit itself.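

Compound 3 gives > 50000 nM in this assay, a limit and not a number. Compound 2 also sits at a limit, so bromo in place of iodo yields no readable step between compound 2 and compound 3: the limit of > 50000 nM in this assay, at which 3 of the 3 values shown sit.

The compounds shown leave open how far each lies from that limit, and which change on the shared core would give a numbered potency.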